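This account rests on a few compounds, and the source may have more. Where it says the series, first, only, none or still open, it means among the compounds named here.

Working notes on the series. In a functional assay for activation of Alpha-1D adrenergic receptor (Homo sapiens), read by calcium flux (on this read-out lower numbers stand for an effect already at smaller amounts and higher numbers for an effect only at larger amounts of compound), compound 1 `c1cncc(-c2ccccc2OCC2=NCCN2)c1` gives 158 nM, compound 2 `c1ccc(-c2ccns2)c(OCC2=NCCN2)c1` gives 25.1 nM and compound 3 `c1ccc(-c2nccs2)c(OCC2=NCCN2)c1` gives 31.6 nM. Compound 3 thus stands second highest of the three numbers; its gap to compound 2 lies within the scatter, its gap to compound 1 beyond it. Compound 4 `Cc1ccoc1-c1ccccc1OCC1=NCCN1` differs from compound 3 by 3-methylfuran-2-yl in place of 1,3-thiazol-2-yl on an aromatic carbon. For the measured compounds named here, the steps that bear on this are a 6.3-fold lower number from compound 1 to compound 2 (0.80 log units; beyond the scatter) and a 5.0-fold lower number from compound 1 to compound 3 (0.70 log units; beyond the scatter), both modest moves away from pyridin-3-yl, while a 1.3-fold higher number from compound 2 to compound 3 (0.10 log units; within the scatter) shows that exchanging one five-membered ring for another stayed within the scatter. For compound 4 no step beyond the scatter in this assay is expected, giving a 1.0-fold higher number from compound 3 to compound 4 (0.01 log units; within the scatter). The estimate for compound 4 is 32 nM, ranging from 10 nM to 100 nM.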

Compound 4, half-maximal effective concentration: < 100000 nM
Compound 4 was reported as a limit (the forecaster's own chance of this, stated with the estimate: 3%); the middle value is on the limit's open side.
By their numbers in this assay, from the lowest: compounds 2 and 3 (each within the scatter of the next); then compound 1.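

In this assay compound 4 gives < 100000 nM, which is a limit and not a number. Its steps from compound 1, compound 2 and compound 3 cannot be read. The compounds shown leave open how 3-methylfuran-2-yl compares with 1,3-thiazol-2-yl, 1,2-thiazol-5-yl and pyridin-3-yl on this read-out.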